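Swapping a Hydantoin for an Acetate on an Oxazolidinone

The source may report more compounds than this note shows. Statements on the series, on what has been measured and on what is new or still open speak of the compounds shown alone.

Compound 1 `CCN1CCN(C[C@H]2CN(c3ccc(-n4cc(-c5ccccn5)cn4)c(F)c3)C(=O)O2)CC1`: in an ADME assay on L02 cells (Homo sapiens) for cytotoxicity, read by MTT assay, with a stated time of 48 h (a lower number here means a stronger inhibitor, a higher number a weaker inhibitor), compound 1 gives 99 ug/mL.
Compound 2 `O=C1CNC(=O)N1C[C@H]1CN(c2ccc(-n3cc(-c4ccccn4)cn3)c(F)c2)C(=O)O1`: in this assay compound 2 gives > 400 ug/mL, which is a limit of the assay and not a number.

Compound 2 thus stands at the weak end of the two values shown, since (the limit of > 400 ug/mL in this assay, at which 1 of the 2 values shown sits). Among the compounds with values here, the one measured step, an at least 4.0-fold higher number from compound 1 to compound 2 (0.60 log units; beyond the scatter), moved toward a weaker number. Compound 3 `CC(=O)OC[C@H]1CN(c2ccc(-n3cc(-c4ccccn4)cn3)c(F)c2)C(=O)O1` is the compound not yet measured. It differs from compound 2 in one place: acetoxy in place of 2,5-dioxoimidazolidin-1-yl on a saturated chain carbon bound to a saturated ring carbon. Within the data shown here, this again exchanges a group with no net charge for another with no net charge, and no measured pair shows what an acetoxy does here. Compound 2 already sits at the limit. The step of a number no higher from compound 2 to compound 3 (the limit leaves the size open) is therefore expected to be small or none beyond the scatter, most likely ending at the limit again. Compound 3 is estimated at 400 ug/mL in this assay, with a range from 150 ug/mL to 900 ug/mL.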

Compound 3, half-maximal inhibitory concentration: > 400 ug/mL
Compound 3 gave a limit, no number; the forecaster's own chance of this, stated with the estimate: 55%; the middle value lies on the limit itself.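

In this assay compound 3 gives > 400 ug/mL as well, which is a limit of the assay and not a number. On this saturated chain carbon bound to a saturated ring carbon, acetoxy in place of 4-ethylpiperazin-1-yl gives an at least 4.0-fold higher number from compound 1 to compound 3 (0.60 log units; beyond the scatter) and so shows that a replacement without a ring can match the change already seen with 2,5-dioxoimidazolidin-1-yl, while the step between the two limits cannot be read. Two quite different groups now end at the same point, which is where the read-out stops giving numbers: the limit of > 400 ug/mL in this assay, at which 2 of the 3 values shown sit.

From the compounds shown here alone, how far beyond the limit compound 2 and compound 3 lie stays unknown, so these two groups cannot be ranked against each other. Going by these compounds, whether a primary amine or a carboxylic acid on the same carbon would give a number within the range of the assay also stays open.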